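The source may hold more compounds than are shown below. What is called first, only, known or untested is meant among the compounds shown, and "the series" means these compounds.

In a physicochemical assay, with a stated time of 6 min (a lower number here means a stronger inhibitor, a higher number a weaker inhibitor), compound 3 `O=C(Nc1ccc(F)cc1)Nc1nc(-c2cc3cc(Br)ccc3o2)cs1` gives > 200000 nM, which is a limit of the assay and not a number. Compound 4 `O=C(Nc1ccc(F)cc1)Nc1nc(-c2cc3cc([N+](=O)[O-])ccc3o2)cs1` differs from it as follows: nitro in place of bromo on an aromatic carbon. In words, this is nitro in place of bromo on an aromatic carbon. Going by the values given here, no measured step covers this exact swap. The nearest evidence comes from two compounds that already carry the nitro: compound 1 `O=C(Nc1ccccc1)Nc1nc(-c2cc3cc([N+](=O)[O-])ccc3o2)cs1` gives 183000 nM and compound 2 `O=C(Nc1ccc(I)cc1)Nc1nc(-c2cc3cc([N+](=O)[O-])ccc3o2)cs1` gives 62400 nM. That is a 2.9-fold lower number from compound 1 to compound 2 (0.47 log units; beyond the scatter), for iodo in place of hydrogen on an aromatic carbon. A modest move to a lower number in this assay is expected, because compound 1 with its nitro gives 183000 nM. The estimated change is an at least 1.6-fold lower number from compound 3 to compound 4 (0.22 log units; that floor lies within the scatter). For compound 4 the expected value is 120000 nM, with an estimated range from 50000 nM to 200000 nM.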

Compound 4, half-maximal inhibitory concentration: 123000 nM
Estimate against measurement, compound 4: 1.0-fold (0.01 log units) below; low and high end bracket the measured number.
By their numbers in this assay, from the lowest: compounds 2, 4 and 1 (each within the scatter of the next, the first and the last beyond it). At a limit, above all of these: compound 3.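

In this assay compound 3 gives > 200000 nM, which is a limit and not a number: the limit of > 200000 nM in this assay, at which 1 of the 4 values shown sits. Nitro in place of bromo gives an at least 1.6-fold lower number from compound 3 to compound 4 (0.21 log units; that floor lies within the scatter), so the size of this swap stays unfixed. With nitro kept, fluoro gives a 1.5-fold lower number from compound 1 to compound 4 (0.17 log units; within the scatter) and a 2.0-fold higher number from compound 2 to compound 4 (0.29 log units; within the scatter), so fluoro cannot be told apart from hydrogen or from iodo here, although compounds 1 and 2 do differ beyond the scatter.

From the compounds shown here alone, what an amine or a carboxylic acid would give in place of the nitro stays open.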